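Swapping the side chain from compound 3 to compound 4

The compounds below may be only part of what the source reports. "The series", "measured", "known", "first", "only" and "open" are said of these compounds alone.

Compound 1 `COc1ccc2cc(-c3ccccc3)c(O)nc2c1`, compound 2 `COc1ccc(-c2cc3cccc(OC)c3nc2O)cc1` and compound 3 `CCOC(=O)Cn1c(=O)c(-c2ccc(OC)cc2)cc2c(OC)cc(OC)cc21` have all been tested in a functional assay on A549 cells (Homo sapiens) for cytotoxicity, read by colorimetric assay and MTT assay; a lower number here means a stronger inhibitor, a higher number a weaker inhibitor. Compound 1 gives 10000 nM, compound 2 gives 10000 nM, and compound 3 gives 10000 nM, so compound 3 stands level with both at the digits shown, within the scatter of either. Compound 4 `CCN(CC)C(=O)CCn1c(=O)c(-c2ccc(OC)cc2)cc2c(OC)cc(OC)cc21` has not yet been measured in this assay; it differs from compound 3 by (diethylcarbamoyl)methyl in place of ethoxycarbonyl on a saturated chain carbon bound to an aromatic nitrogen. Among the compounds with values here, no step between measured compounds is available to guide the size of this change, and nothing in the three values separates one compound from another. The step of no change at the digits printed from compound 3 to compound 4 (within the scatter) is therefore expected to stay within the scatter, in no particular direction. In this assay compound 4 is estimated at 10000 nM, with a range from 5000 nM to 20000 nM.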

Compound 4, half-maximal inhibitory concentration: 10000 nM
Beside the measured number, compound 4's estimate shows no gap at the digits printed; measured number inside the range.
By their numbers in this assay, from the lowest: compounds 1, 2, 3 and 4 (each within the scatter of the next).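

In this assay, within the data shown here, (diethylcarbamoyl)methyl in place of ethoxycarbonyl on a saturated chain carbon bound to an aromatic nitrogen gives no change at the digits printed from compound 3 to compound 4 (within the scatter), the first step that can be read at this position. This exchange of the ester for the larger amide side chain therefore leaves the printed value in place. Nothing available explains this result.

From the compounds shown here alone, whether any side chain here can shift the value remains open, since compound 4 still gives 10000 nM. A carboxylic acid or a primary amine at the end of this chain could test that.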